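The source may hold more compounds than are shown below. What is called first, only, known or untested is meant among the compounds shown, and "the series" means these compounds.

In a functional assay on MCF7 cells (Homo sapiens) for antiproliferative activity (on this read-out lower numbers stand for stronger inhibition and higher numbers for weaker inhibition), compound 1 `CC(C)=CCc1cc(C(=O)Nc2cc3ccc(OCCCNC(C)(C)C)c(C)c3oc2=O)ccc1O` gives 950 nM and compound 2 `CC(C)=CCc1cc(C(=O)Nc2cc3ccc(OCCCN(C)C(C)(C)C)c(C)c3oc2=O)ccc1O` gives 1140 nM, a pair separated by a 1.2-fold higher number from compound 1 to compound 2 (0.08 log units; within the scatter). Compound 3 `CC(C)=CCc1cc(C(=O)Nc2cc3ccc(OCCCN(C)c4ccccc4)c(C)c3oc2=O)ccc1O` stands at > 50000 nM, which is a limit of the assay and not a number. Compound 4 `CC(C)=CCc1cc(C(=O)Nc2cc3ccc(OCCCNC(C)(C)c4ccccc4)c(C)c3oc2=O)ccc1O` differs from compound 3 as follows: (1-methyl-1-phenylethyl)amino in place of methyl(phenyl)amino on a saturated chain carbon, three bonds along the chain from an oxygen on an aromatic ring. Its amine nitrogen carries a hydrogen again, as in compound 1, and 1-methyl-1-phenylethyl instead of phenyl. Within the data shown here, two measured steps bear on this change, both large: an at least 52-fold higher number from compound 1 to compound 3 (1.72 log units; beyond the scatter) and an at least 43-fold higher number from compound 2 to compound 3 (1.64 log units; beyond the scatter). Reversing that loss, at least in good part, is the expectation, so a large move toward lower numbers is expected in this assay. The estimated step is an at least 20-fold lower number from compound 3 to compound 4 (1.30 log units; beyond the scatter). Compound 4 is estimated at 2500 nM, within a range of 600 nM to 15000 nM.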

Compound 4, half-maximal inhibitory concentration: 1070 nM
Compound 4: middle estimate off by 2.3-fold (0.37 log units), on the high side; measured number inside the range.
By their numbers in this assay, from the lowest: compounds 1, 4 and 2 (each within the scatter of the next). At a limit, above all of these: compound 3.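

A phenyl ring in the amine group does not by itself end activity at this position: moved from the nitrogen onto a saturated carbon bound to it, the ring comes with an at least 46-fold lower number from compound 3 to compound 4 (1.66 log units; beyond the scatter). Compound 3 stands at a limit of the assay, not at a number: the limit of > 50000 nM in this assay, at which 1 of the 4 values shown sits. Phenyl in place of methyl on that carbon leaves the read-out within the scatter, with a 1.1-fold higher number from compound 1 to compound 4 (0.05 log units; within the scatter), and the comparison with the other active amine gives a 1.1-fold lower number from compound 2 to compound 4 (0.03 log units; within the scatter).

Still open, going by these compounds, is how a benzyl group on the nitrogen, a piperidine ring in place of the open amine, or a longer chain to the amine would fare.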